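A few compounds are considered here, and "the series" means these few. Any claim that something is new, unique, unknown or untested is made for them only; others in the source may bear on it.

Among the measured compounds shown here, compound 2 `COc1cc(N/C(CCNC2=CC(=O)c3ccccc3C2=O)=N\S(=O)(=O)c2ccc(C)cc2)cc(OC)c1OC` gives 9330 nM in a functional assay on DU-145 cells (Homo sapiens) for cytotoxicity, read by MTT assay, with a stated time of 48 h (a lower number here means a stronger inhibitor, a higher number a weaker inhibitor), and stands beside the only other number measured, that of compound 1 `Cc1ccc(S(=O)(=O)/N=C(/CCNC2=CC(=O)c3ccccc3C2=O)Nc2ccccc2I)cc1` at 11700 nM; the step of a 1.3-fold lower number from compound 1 to compound 2 (0.10 log units; within the scatter) stays within the scatter. Compound 3 `Cc1ccc(S(=O)(=O)/N=C(/CCNC2=CC(=O)c3ccccc3C2=O)NC(C)C)cc1` differs from compound 2 by isopropyl in place of 3,4,5-trimethoxyphenyl on an amine nitrogen. For the measured compounds named here, the one measured step at this amine nitrogen, from compound 1 to compound 2, was small, so no shift beyond the scatter is expected in this assay, though an aryl-to-alkyl swap is untested here. Compound 3 is therefore estimated at 12000 nM, between 4000 nM and 40000 nM, a step of a 1.3-fold higher number from compound 2 to compound 3 (0.11 log units; within the scatter).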

Compound 3, half-maximal inhibitory concentration: 28500 nM
Estimate against measurement, compound 3: 2.4-fold (0.38 log units) below, within the range that was stated.
By their numbers in this assay, from the lowest: compounds 2 and 1 (each within the scatter of the next); then compound 3.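

On this amine nitrogen, isopropyl moves the number beyond the scatter in this assay, giving a 3.1-fold higher number from compound 2 to compound 3 (0.48 log units; beyond the scatter) and a 2.4-fold higher number from compound 1 to compound 3 (0.39 log units; beyond the scatter) (both modest). The two aryl groups, 3,4,5-trimethoxyphenyl and 2-iodophenyl, remain within the scatter of each other, so only the change from aryl to isopropyl registers at this position. No measurement shown explains this shift. As far as these compounds go, it remains open whether the aromatic ring itself matters or the kind of group more broadly. A cyclohexyl, a benzyl or a longer alkyl chain on this nitrogen would help separate those readings.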